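Para-substituent swap on the thiosemicarbazone series: methyl to methoxy

A few compounds are considered here, and "the series" means these few. Any claim that something is new, unique, unknown or untested is made for them only; others in the source may bear on it.

Measured so far in a functional assay on MCF7 cells (Homo sapiens) for inhibition, read by sulforhodamine B assay, with a stated time of 48 h; a higher number here means a weaker inhibitor of growth, a lower number a stronger inhibitor of growth:
- compound 1 `CCc1ccc(NC(=S)N/N=C/c2cccs2)cc1`: > 100000 nM
- compound 2 `Cc1ccc(NC(=S)N/N=C/c2cccs2)cc1`: 38600 nM
- compound 3 `C=CCNC(=S)N/N=C/c1cccs1`: > 100000 nM

The values for compound 1 and compound 3 are limits of the assay, not numbers. Going by the values given here, compound 2 is therefore the only compound with a measured number; the two other values shown are limits, a situation summarised in the limit of > 100000 nM in this assay, at which 2 of the 3 values shown sit. Among the compounds with values here, the one measured step, an at least 2.5-fold lower number from compound 1 to compound 2 (0.41 log units; beyond the scatter), is the sole comparison available, and it does not touch the group that now changes.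

Compound 4 `COc1ccc(NC(=S)N/N=C/c2cccs2)cc1` differs from compound 2 by methoxy in place of methyl on an aromatic carbon. Within the data shown here, no measured step bears on this exchange: the ethyl-to-methyl step concerns the size of an alkyl group, not the introduction of an oxygen. With nothing to point either way, the number for compound 4 is expected to stay near that of compound 2, as a 1.2-fold higher number from compound 2 to compound 4 (0.07 log units; within the scatter), with a real chance that this assay again reports only a limit. The estimate for compound 4 in this assay is therefore 45000 nM, expected to fall between 15000 nM and 100000 nM.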

Compound 4, concentration for 50% growth inhibition: > 100000 nM
Compound 4 was reported as a limit; the forecaster's own chance of this, stated with the estimate: 35%; at least 2.2-fold (0.34 log units) between middle value and limit.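

In this assay, the place para to a large group on the six-membered aromatic ring now has a second exchange away from methyl, and methoxy in place of methyl gives an at least 2.5-fold higher number from compound 2 to compound 4 (0.41 log units; beyond the scatter). Ethyl and methoxy thus both separate from methyl in the same direction, which leaves methyl as the only group at this place with a measured number, while the step between compound 1 and compound 4 cannot be read, both values being limits. The series now rests largely on a single limit: the limit of > 100000 nM in this assay, at which 3 of the 4 values shown sit.

Going by these compounds, how much of the activity of compound 2 depends on methyl itself remains open, and so does the order among the compounds at the limit. A fluorine atom or an amine at this place would test whether any group other than methyl keeps a measurable number.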